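Aryl urea series: thermal shift notes toward compound 3

The source may report more compounds than this note shows. Statements on the series, on what has been measured and on what is new or still open speak of the compounds shown alone.

Compound 1 `Cc1ccc(F)cc1NC(=O)Nc1cc(C(C)(C)C)nn1-c1ccccc1`: 6 degrees C
Compound 2 `COc1cccc(NC(=O)Nc2cc(C(C)(C)C)nn2-c2ccccc2)c1`: 3.6 degrees C

In an assay on isolated protein for inhibition of STE20-like serine/threonine-protein kinase (Homo sapiens), read by thermal shift assay, tested at 10 uM (a higher number here means that the compound stabilises the target more against heat, a lower number that the compound stabilises the target less), compound 1 gives 6 degrees C, while compound 2 gives 3.6 degrees C, the lowest of the two numbers measured. Compound 3 `Cc1ccc(NC(=O)Nc2cc(C(C)(C)C)nn2-c2ccccc2)cc1` differs from compound 2 by 4-methylphenyl in place of 3-methoxyphenyl on an amide-type nitrogen. Among the measured compounds shown here, the one measured step that bears on this change is the earlier aryl swap on the same amide-type nitrogen, a number 2.4 degrees C lower from compound 1 to compound 2 (beyond the scatter), modest but beyond the scatter. A change of similar size is therefore plausible here, though its direction cannot be read from a single step. For compound 3 the expected value in this assay is 4.5 degrees C, with a range of 2.5 degrees C to 6.5 degrees C. This estimate means an expected step of a number 0.90 degrees C higher from compound 2 to compound 3 (within the scatter).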

Compound 3, shift of the target's melting temperature: 4.6 degrees C
Compound 3: the middle estimate sits 0.10 degrees C below what was measured; low and high end bracket the measured number.
By their numbers in this assay, from the lowest: compounds 2 and 3 (each within the scatter of the next); then compound 1.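

On the amide-type nitrogen, 4-methylphenyl in place of 3-methoxyphenyl gives a step within the scatter (a number 1.0 degrees C higher from compound 2 to compound 3 (within the scatter)), so these two aryl groups cannot be told apart here. Replacing 5-fluoro-2-methylphenyl with 4-methylphenyl gives a step beyond the scatter (a number 1.4 degrees C lower from compound 1 to compound 3 (beyond the scatter)), which leaves 5-fluoro-2-methylphenyl above both other aryl groups shown. No measured evidence accounts for either step.

From the compounds shown here alone, it remains open whether the higher number of compound 1 depends on the fluorine, the methyl or both together. Going by these compounds, how an aryl group carrying an amine or a carboxylic acid reads on this nitrogen also remains open.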